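Ether substituent variation: compound 2 to compound 3

This account rests on a few compounds, and the source may have more. Where it says the series, first, only, none or still open, it means among the compounds named here.

Measured so far:
compound 1 `CN(c1ccc([N+](=O)[O-])cc1OC1CCCCC1)S(C)(=O)=O` gives 470 nM in an assay on SK-BR-3 cells for inhibition of Aromatase (Homo sapiens); on this read-out lower numbers stand for stronger inhibition and higher numbers for weaker inhibition.
compound 2 `CCCOc1cc([N+](=O)[O-])ccc1N(C)S(C)(=O)=O` gives 760 nM in this assay.

Going by the values given here, compound 2 carries the higher of the two numbers, with compound 1 as its only neighbour; the step of a 1.6-fold higher number from compound 1 to compound 2 (0.21 log units; within the scatter) is within the scatter, so the two compounds cannot be ranked against each other on these data.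

Compound 3 `CC(C)Oc1cc([N+](=O)[O-])ccc1N(C)S(C)(=O)=O` differs from compound 2 in one place: isopropyl in place of propyl on an oxygen on an aromatic ring. The two have the same atoms, joined differently.

Among the compounds with values here, only one measured step exists, and it concerns the same oxygen on the aromatic ring: cyclohexyl to propyl, a larger change in shape than propyl to isopropyl, which nevertheless left the number within the scatter. Within the data shown here, no measured pair shows a propyl-to-isopropyl exchange directly, so the expectation rests on that single step alone.

Against this background no step beyond the scatter is expected from compound 2 to compound 3 in this assay; the expected step is a 1.1-fold lower number from compound 2 to compound 3 (0.04 log units; within the scatter). Compound 3 is therefore estimated at 700 nM, with a range of 300 nM to 1700 nM.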

Compound 3, half-maximal inhibitory concentration: 2810 nM
Compound 3: middle estimate off by 4.0-fold (0.60 log units), on the low side, and the stated range ends below it.
By their numbers in this assay, from the lowest: compounds 1 and 2 (each within the scatter of the next); then compound 3.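

In this assay this oxygen substituent proves sensitive to an exchange that keeps the same atoms and only joins them differently: isopropyl in place of propyl gives a 3.7-fold higher number from compound 2 to compound 3 (0.57 log units; beyond the scatter) and lies beyond the scatter, whereas the earlier exchange of cyclohexyl for propyl stayed within it. Isopropyl in place of cyclohexyl gives a 6.0-fold higher number from compound 1 to compound 3 (0.78 log units; beyond the scatter) and also lies beyond the scatter, so compound 3 shows the weakest inhibition of the three, and the numbers do not follow the size of the group, since compound 1 and compound 2 remain within the scatter of each other despite their very different substituents. No supporting measurement bears on this result, and the cause of the step remains unknown.

The three compounds leave open whether the higher number is particular to isopropyl or also appears with other groups on this oxygen, such as cyclopropyl, tert-butyl or a longer chain like butyl. They also leave open whether the same exchange would give a step of similar size with an amine in place of the nitro group on the shared core.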